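Butylcarbamoyl for Fluoro on the Fused Ring

The source may hold more compounds than are shown below. What is called first, only, known or untested is meant among the compounds shown, and "the series" means these compounds.

Compound 1 `CC[C@@H]1C(=O)N(C)c2cnc(-n3ccc4cc(F)ccc43)nc2N1C1CCCC1` gives 46500 nM in a functional assay on NCI-H1975 cells (Homo sapiens) for antiproliferative activity, read by CCK-8 assay, with a stated time of 72 h (on this read-out lower numbers stand for stronger inhibition of growth and higher numbers for weaker inhibition of growth), the highest of the two numbers recorded in that assay. Compound 2 `CC[C@@H]1C(=O)N(C)c2cnc(Nc3ccc(S(=O)(=O)NCCO)cc3)nc2N1C1CCCC1` gives 2100 nM in this assay, a far lower number, beyond the usual scatter. Compound 3 `CCC1C(=O)N(C)c2cnc(Nc3ccc(S(=O)(=O)NCCO)cc3)nc2N1c1ccn(C)n1` is reported in this assay as "not active" (no number reported), with no number given. Within the data shown here, no pair of measured compounds differs in just one place, so no single step is available to anchor the change at hand. Compound 4 `CCCCNC(=O)c1ccc2c(ccn2-c2ncc3c(n2)N(C2CCCC2)[C@H](CC)C(=O)N3C)c1` differs from compound 1 by butylcarbamoyl in place of fluoro on an aromatic carbon. With no comparable change among the measured compounds, only a tentative view is possible: a modest move toward stronger growth inhibition is expected, with no change beyond the scatter well within range. The expected step is a 3.1-fold lower number from compound 1 to compound 4 (0.49 log units; beyond the scatter). Compound 4 is estimated at 15000 nM, between 4000 nM and 50000 nM.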

Compound 4, concentration for 50% growth inhibition: 990 nM
For compound 4 the middle estimate is 15-fold (1.18 log units) above the measured one; measured number outside the range, below it.
By their numbers in this assay, from the lowest: compound 4; then compound 2; then compound 1.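

In this assay, butylcarbamoyl in place of fluoro on this aromatic carbon gives a 47-fold lower number from compound 1 to compound 4 (1.67 log units; beyond the scatter), the first single-place step available in this series. It shows that growth inhibition responds strongly to the group at this position, and that the much larger butylcarbamoyl group is accepted there. Nothing at hand accounts for the size of this step.

Going by these compounds, it remains open whether the change rests on the amide or on the butyl chain. A carboxylic acid, an unsubstituted carboxamide or a longer chain on this carbon would bear on that question.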